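Solubility notes on the series: compound 4 pending

This account rests on a few compounds, and the source may have more. Where it says the series, first, only, none or still open, it means among the compounds named here.

Measured so far:
compound 1 `CN1CCC(C(=O)N2Cc3c(NC(=O)C4CCC4)n[nH]c3C2(C)C)CC1` gives > 225000 nM in a physicochemical assay for solubility, at pH 7; on this read-out higher numbers stand for higher solubility and lower numbers for lower solubility; this is a limit of the assay.
compound 2 `CC1(C)c2[nH]nc(NC(=O)c3ccc(F)cc3)c2CN1C(=O)C1CCN(C2CC2)CC1` gives > 225000 nM in this assay; this too is a limit.
compound 3 `CCN1CCC(C(=O)N2Cc3c(NC(=O)CC(C)C)n[nH]c3C2(C)C)CC1` gives > 225000 nM in this assay; again a limit.

Compound 1 therefore stands where every measured compound of the series stands: at the limit, with no number of its own. Among the compounds with values here, the evidence to hand is the single observation (the limit of > 225000 nM in this assay, at which 3 of the 3 values shown sit), so no real step between measured compounds can be read, and the three compounds cannot be ranked against one another.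

Compound 4 `CN1CCC(C(=O)N2Cc3c(NC(=O)c4ccncc4)n[nH]c3C2(C)C)CC1` is not yet measured. It differs from compound 1 by pyridin-4-yl in place of cyclobutyl on a carbonyl carbon.

Because (the limit of > 225000 nM in this assay, at which 3 of the 3 values shown sit), the working expectation is that compound 4 will again be reported at the limit rather than as a number. The step from compound 1 to compound 4 is thus expected as a number no higher from compound 1 to compound 4 (the limit leaves the size open), that is, none beyond the scatter in this assay. For compound 4 the estimate is 225000 nM, with a range from 80000 nM to 450000 nM.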

Compound 4, solubility: > 225000 nM
Compound 4: only a limit was reported; the forecaster's own chance of this, stated with the estimate: 70%; the middle value sits exactly at the limit.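

Compound 4, like compound 1, is reported only as a limit in this assay, so no step from compound 1 to compound 4 can be read: the limit of > 225000 nM in this assay, at which 4 of the 4 values shown sit.

The compounds shown leave open whether pyridin-4-yl in place of cyclobutyl on a carbonyl carbon shifts the read-out at all, and how compound 1, compound 2, compound 3 and compound 4 rank against one another.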